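Notes on a fluoro step on the phenyl amide

The compounds below may be only part of what the source reports. "The series", "measured", "known", "first", "only" and "open" are said of these compounds alone.

In an ADME assay on BaF3 cells (Mus musculus) for antiproliferative activity, read by CCK-8 assay, with a stated time of 72 h (a lower number here means a stronger inhibitor of growth, a higher number a weaker inhibitor of growth), compound 3 `O=C(CCSc1ccc2c(/C=C/c3ccccn3)n[nH]c2c1)Nc1ccccc1` gives 690 nM. Compound 1 `Cc1ccc(C(=O)Nc2ccc(CN3CCN(C)CC3)c(C(F)(F)F)c2)cc1C#Cc1ncc2cccnn12` gives 940 nM, within the scatter of the value for compound 3. Compound 2 `CNC(=O)CCSc1ccc2c(/C=C/c3ccccn3)n[nH]c2c1` reads > 10000 nM, which is a limit of this assay and not a number.

Compound 4 `O=C(CCSc1ccc2c(/C=C/c3ccccn3)n[nH]c2c1)Nc1cccc(F)c1` carries fluoro in place of hydrogen on an aromatic carbon of the phenyl of compound 3, meta to a large group: fluoro in place of hydrogen on an aromatic carbon. For the measured compounds named here, the only measured step that bears on this change is an at least 14-fold lower number from compound 2 to compound 3 (1.16 log units; beyond the scatter). That large step put phenyl in place of methyl on an amide-type nitrogen, so it sets no size for a single fluoro on the phenyl. Going by the values given here, no measured step changes a substituent on that phenyl. The expected result in this assay is therefore no shift beyond the scatter in either direction, with an estimated 1.2-fold lower number from compound 3 to compound 4 (0.06 log units; within the scatter). Compound 4 is estimated at 600 nM, with an expected range of 200 nM to 1700 nM.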

Compound 4, concentration for 50% growth inhibition: 6590 nM
For compound 4 the middle estimate is 11-fold (1.04 log units) below the measured one; the measured number lies above the stated range.
By their numbers in this assay, from the lowest: compounds 3 and 1 (each within the scatter of the next); then compound 4. At a limit, above all of these: compound 2.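

The phenyl of the amide does not tolerate every small change in this assay: a single fluoro in place of hydrogen on that ring gives a clear loss (a 9.6-fold higher number from compound 3 to compound 4 (0.98 log units; beyond the scatter)). Most of the gain from the phenyl step (an at least 14-fold lower number from compound 2 to compound 3 (1.16 log units; beyond the scatter)) does not carry over to 3-fluorophenyl (an at least 1.5-fold lower number from compound 2 to compound 4 (0.18 log units; that floor lies within the scatter)). That last step gives only a floor, set by the value of compound 2, which is a limit of the assay and not a number: the limit of > 10000 nM in this assay, at which 1 of the 4 values shown sits.

Still open, on these data alone, is whether the loss belongs to fluoro itself or to this place on the ring, which chloro or methoxy at the same place, or fluoro elsewhere on the phenyl, would separate. As far as these compounds go, it is also open whether an amine or a carboxylic acid on that phenyl would keep the level of compound 3.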